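One Group Swapped, the Cell Reading Still Open

This account rests on a few compounds, and the source may have more. Where it says the series, first, only, none or still open, it means among the compounds named here.

Two related compounds have so far been tested in a functional assay on Huh-5-2 cells (Homo sapiens), read by MTT assay; a lower number here means that less compound is tolerated, a higher number that more compound is tolerated. Compound 1 (`CC(=O)c1ccc(-c2ccc(Cl)cc2)c(COc2ccc(-c3nc4cc(C(=O)O)ccc4n3C3CCCCC3)cc2)c1`) gives 24000 nM. Compound 2 (`CCCNC(=O)c1ccc(-c2ccc(Cl)cc2)c(COc2ccc(-c3nc4cc(C(=O)O)ccc4n3C3CCCCC3)c(F)c2)c1`) gives 24000 nM, which puts it level with compound 1. These two structures differ in more than one place, so their shared reading does not isolate the effect of any single change.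

Compound 3 (`CC(=O)N(C)c1ccc(-c2ccc(Cl)cc2)c(COc2ccc(-c3nc4cc(C(=O)O)ccc4n3C3CCCCC3)c(F)c2)c1`) has not yet been measured. It keeps the rest of compound 2 but carries acetyl(methyl)amino in place of propylcarbamoyl on an aromatic carbon, para to a 4-chlorophenyl group (acetyl(methyl)amino in place of propylcarbamoyl on an aromatic carbon). Among the measured compounds shown here, no measured pair shows this exact swap, so any forecast is tentative. For the measured compounds named here, the only guide is that compound 1, at 24000 nM, and compound 2, at 24000 nM, carry different groups at this carbon and still read level.

The step expected in this assay, no change at the digits printed from compound 2 to compound 3 (within the scatter), is estimated to stay within the usual scatter, with neither direction favoured. For compound 3 the expected value is 24000 nM, with an estimated range from 11000 nM to 50000 nM.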

Compound 3, half-maximal cytotoxic concentration: 26000 nM
Compound 3: middle estimate off by 1.1-fold (0.03 log units), on the low side; the range from low to high includes it.
By their numbers in this assay, from the lowest: compounds 1, 2 and 3 (each within the scatter of the next).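

In this assay, putting acetyl(methyl)amino in place of propylcarbamoyl gives a 1.1-fold higher number from compound 2 to compound 3 (0.03 log units; within the scatter). This is the only comparison shown that isolates a single change at this aromatic carbon, para to a 4-chlorophenyl group, so the level reading can now be tied to one swap rather than to several differences at once. The swap goes from 6 heavy atoms to 5 and from 1 hydrogen-bond donor to 0 on this group, and the tolerated concentration in these cells stays within the scatter, though nothing shown here accounts for that outcome.

Only these two groups have been compared directly at this carbon, so the compounds shown leave open whether a simple amine, a carboxylic acid or a longer chain there would also read level. They also leave open how the same swap would read outside this assay and whether it would hold with the rest of the molecule changed, for example in a compound without the fluorine of compound 2.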